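A few compounds are considered here, and "the series" means these few. Any claim that something is new, unique, unknown or untested is made for them only; others in the source may bear on it.

Of the compounds shown here, two have been read in an assay on membranes from CHO cells for displacement of a labelled ligand from adenosine receptor A1 (Homo sapiens), read by scintillation counting, with a stated time of 60 min, tested at 1 uM; a higher number here means more inhibition at the concentration tested (going by the name of the read-out), a lower number less inhibition. Compound 1 `COC(=O)C1=C(C)NC(=O)NC1c1ccoc1` gives 8% in this assay. Compound 2 `CCCOC(=O)C1=C(C)NC(=S)NC1c1ccco1` gives 1% in this assay. Compound 2 holds the lower of the two numbers, but its gap to compound 1 lies within the scatter of repeated measurements, so the pair shows one thing only: little inhibition at the concentration tested for either. Among the measured compounds shown here, compound 1 and compound 2 differ in more than one place and no single step between them is set out, so nothing further is drawn from the pair.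

Compound 3 `CC1=C(C(=O)OCC(C)C)C(c2ccco2)NC(=S)N1` is the next member and is not yet measured. It differs from compound 2 by methyl in place of hydrogen on a saturated chain carbon bound to two saturated chain carbons. For the measured compounds named here, the only anchor for compound 3 is compound 2, whose value in this assay is 1%. Going by the values given here, with a change of this kind and no measured step of its kind, the expected step of a number 2 percentage points higher from compound 2 to compound 3 (within the scatter) is none beyond the scatter, in either direction. Compound 3 is therefore expected to give 3% in this assay, with a range from -8% to 14%.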

Compound 3, a percentage reported as inhibition, at one concentration (the size of the read-out at that concentration, not a potency): 7%
For compound 3 the middle estimate is 4 percentage points below the measured one; the measured number falls inside the stated range.
By their numbers in this assay, from the lowest: compounds 2, 3 and 1 (each within the scatter of the next).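

In this assay, among the compounds shown here, the first single-place step reads a number 6 percentage points higher from compound 2 to compound 3 (within the scatter), for methyl in place of hydrogen on a saturated chain carbon bound to two saturated chain carbons, the change that turns propoxy into isobutoxy. This change at this place therefore produces no shift that can be told from the scatter, and with compound 3 at 7% the series still shows little inhibition at the concentration tested. No evidence on the cause of this result is at hand.

For the compounds shown here, whether a longer chain such as hexyl, or a chain ending in an amine or a carboxylic acid, would move the number beyond the scatter at this place remains open, since one methyl is the only change read here. Also open, from the compounds shown here alone, is what a swap of the thiocarbonyl for a carbonyl would do on its own, as compound 1 and compound 2 differ in more than one place and say nothing about that change alone.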